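The compounds below may be only part of what the source reports. "The series", "measured", "known", "first", "only" and "open" are said of these compounds alone.

Compound 3 `O=C(NC[C@]1(CC2CC2)[C@@H]2CN(S(=O)(=O)CC3CC3)C[C@@H]21)c1ccc(Cl)cc1Cl` carries a cyclopropylmethyl group on its sulfonyl sulfur and a dichlorobenzamide on the shared core. In an assay on isolated protein for inhibition of sodium- and chloride-dependent glycine transporter 1 (Homo sapiens) (on this read-out higher numbers stand for weaker inhibition and lower numbers for stronger inhibition), compound 3 gives 230 nM. Of the two compounds with an actual number, this is the higher one; the nearest is compound 2 `Cn1cnc(S(=O)(=O)N2C[C@@H]3[C@H](C2)[C@@]3(CNC(=O)c2ccccc2C(F)(F)F)CC2CC2)c1`, which in this assay gives 5 nM. Compound 1 `O=C(NC[C@]1(CC2CC2)[C@@H]2CN(S(=O)(=O)c3ccccc3F)C[C@@H]21)c1ccc(Cl)cc1Cl` in this assay sits at > 10000 nM, which is a limit of the assay and not a number. Among the compounds with values here, the one measured step that changes the group on the sulfonyl sulfur is an at least 43-fold lower number from compound 1 to compound 3 (1.63 log units; beyond the scatter). Compound 4 `Cn1cnc(S(=O)(=O)N2C[C@@H]3[C@H](C2)[C@@]3(CNC(=O)c2ccc(Cl)cc2Cl)CC2CC2)c1` differs from compound 3 in 1-methyl-1H-imidazol-4-yl in place of cyclopropylmethyl on a sulfonyl sulfur. Within the data shown here, no measured step makes exactly this change. Compound 2 carries the same entering group on its sulfonyl sulfur but a different amide, so its low number is only indirect guidance, while compound 1 shows that a fluorinated benzene ring on the sulfonyl sulfur went with a limit value. Weighing these, a moderate lowering of the number is expected for compound 4, a 3.8-fold lower number from compound 3 to compound 4 (0.58 log units; beyond the scatter). Compound 4 is estimated at 60 nM, with a range from 10 nM to 400 nM.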

Compound 4, half-maximal inhibitory concentration: 4 nM
Beside the measured number, compound 4's estimate is 15-fold (1.18 log units) above it; measured number outside the range, below it.
By their numbers in this assay, from the lowest: compounds 4 and 2 (each within the scatter of the next); then compound 3. At a limit, above all of these: compound 1.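

Within the dichlorobenzamide series, the group on the sulfonyl sulfur has a direct, measured effect in this assay: 1-methyl-1H-imidazol-4-yl in place of cyclopropylmethyl gives a 58-fold lower number from compound 3 to compound 4 (1.76 log units; beyond the scatter), and the same group in place of 2-fluorophenyl gives an at least 2500-fold lower number from compound 1 to compound 4 (3.39 log units; beyond the scatter). With 1-methyl-1H-imidazol-4-yl held on the sulfonyl sulfur, changing the amide from 2-(trifluoromethyl)phenyl to 2,4-dichlorophenyl gives a 1.3-fold lower number from compound 2 to compound 4 (0.10 log units; within the scatter), so these two amides cannot be told apart here, whereas the sulfur group changes the number far beyond the scatter. Compound 1 stands at a limit and not at a number, so the full size of its step stays open: the limit of > 10000 nM in this assay, at which 1 of the 4 values shown sits.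

The compounds shown do not separate which part of 1-methyl-1H-imidazol-4-yl goes with the lower number, since the aromatic ring, its two nitrogens and its methyl all enter together. An imidazole without the methyl, a pyridine ring or a plain methyl on the sulfonyl sulfur would help to tell these parts apart, and the same change with other amides would show how far the step carries over.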